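Trimming the amino ester side chain of compound 2

This account rests on a few compounds, and the source may have more. Where it says the series, first, only, none or still open, it means among the compounds named here.

Compound 2 `COC(=O)[C@@H](CC(C)C)NC(=O)Cn1cc(C2=C(c3c[nH]c4ccccc34)C(=O)N(C)C2=O)c2ccccc21` gives 37400 nM in a functional assay on MCF7 cells (Homo sapiens) for cytotoxicity, read by MTT assay, with a stated time of 24 h; on this read-out higher numbers stand for weaker inhibition and lower numbers for stronger inhibition. For the measured compounds named here, it is one of only two measured compounds; its sole neighbour, compound 1 `COC(=O)CCNC(=O)Cn1cc(C2=C(c3c[nH]c4ccccc34)C(=O)N(C)C2=O)c2ccccc21`, gives 47800 nM in this assay, and the step from one to the other is a 1.3-fold lower number from compound 1 to compound 2 (0.11 log units; within the scatter), so the two cannot be placed one ahead of the other. Compound 3 `COC(=O)[C@@H](C)NC(=O)Cn1cc(C2=C(c3c[nH]c4ccccc34)C(=O)N(C)C2=O)c2ccccc21` has not yet been measured in this assay. It differs from compound 2 by hydrogen in place of isopropyl on a saturated chain carbon, two bonds along the chain from an amide-type nitrogen and a carbonyl carbon. Going by the values given here, the only measured step that bears on this change is a 1.3-fold lower number from compound 1 to compound 2 (0.11 log units; within the scatter), which swapped the entire group on an amide-type nitrogen, an alteration larger than the present one, and it stayed within the scatter. The step from compound 2 to compound 3 is therefore expected to be a 1.1-fold higher number from compound 2 to compound 3 (0.03 log units; within the scatter), nothing beyond the scatter in either direction. Compound 3 is estimated at 40000 nM in this assay, with a range from 15000 nM to 110000 nM. Since both measured numbers are weak, compound 3 is expected to be weak as well.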

Compound 3, half-maximal inhibitory concentration: 15300 nM
Compound 3: middle estimate off by 2.6-fold (0.42 log units), on the high side, within the range that was stated.
By their numbers in this assay, from the lowest: compound 3; then compounds 2 and 1 (each within the scatter of the next).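

In this assay, the saturated chain carbon two bonds along the chain from an amide-type nitrogen and a carbonyl carbon proves to be a place where the number can move: hydrogen in place of isopropyl, which reads as methyl in place of isobutyl on that carbon, gives a 2.4-fold lower number from compound 2 to compound 3 (0.39 log units; beyond the scatter). The same side chain also separates from the unbranched one, as 1-(methoxycarbonyl)ethyl in place of 2-(methoxycarbonyl)ethyl on the amide-type nitrogen gives a 3.1-fold lower number from compound 1 to compound 3 (0.49 log units; beyond the scatter), so compound 3 stands apart from both earlier compounds, though both steps are modest and compound 3 remains a weak compound at 15300 nM. Nothing available accounts for why the methyl-bearing chain gives the lowest number of the three.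

The compounds shown leave open whether the trend from isobutyl to methyl would continue with plain hydrogen on that chain carbon, or whether a benzyl group there would fall with isobutyl or with methyl. They also leave open whether a carboxylic acid in place of the methyl ester, or the opposite configuration at that carbon, would move the number in this assay at all.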